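Replacing Chloro with Cyano on the Aromatic Carbon

The compounds below may be only part of what the source reports. "The series", "measured", "known", "first", "only" and "open" are said of these compounds alone.

Compound 1 `C[C@H]1CC[C@@H]2[C@@H](OC(=O)[C@]23CC(c2ccc(Cl)cc2)=NO3)[C@]2(C)C(=O)C=C[C@@]12O`: 51000 nM
Compound 2 `C[C@H]1CC[C@@H]2[C@@H](OC(=O)[C@]23CC(c2ccc([N+](=O)[O-])cc2)=NO3)[C@]2(C)C(=O)C=C[C@@]12O`: 9000 nM

In a functional assay on SW-620 cells (Homo sapiens) for cytotoxicity, read by sulforhodamine B assay, with a stated time of 48 h (on this read-out lower numbers stand for stronger inhibition and higher numbers for weaker inhibition), compound 1 gives 51000 nM, the higher of the two numbers measured, while compound 2 gives 9000 nM. Among the measured compounds shown here, the single measured step, a 5.7-fold lower number from compound 1 to compound 2 (0.75 log units; beyond the scatter), shows that exchanging the chloro on that aromatic carbon for another group can move this assay well beyond the scatter. Compound 3 `C[C@H]1CC[C@@H]2[C@@H](OC(=O)[C@]23CC(c2ccc(C#N)cc2)=NO3)[C@]2(C)C(=O)C=C[C@@]12O` differs from compound 1 by cyano in place of chloro on an aromatic carbon. The measured step bears on this change only in part, since the entering group there was nitro rather than cyano, and nothing measured shows how cyano itself behaves on this core. Compound 3 is therefore expected to show a 2.6-fold lower number from compound 1 to compound 3 (0.41 log units; beyond the scatter), a lowering judged smaller than the one nitro produced. Compound 3 is estimated at 20000 nM, with a range from 7000 nM to 55000 nM.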

Compound 3, half-maximal inhibitory concentration: 53000 nM
Estimate against measurement, compound 3: 2.7-fold (0.42 log units) below; the measured number falls inside the stated range.
By their numbers in this assay, from the lowest: compound 2; then compounds 1 and 3 (each within the scatter of the next).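

In this assay, the step to the cyano compound reads a 1.0-fold higher number from compound 1 to compound 3 (0.02 log units; within the scatter), so the earlier finding that exchanging chloro at this position, para to a large group, can move the number does not hold for every entering group. Nitro now stands apart from cyano on the same carbon, with a 5.9-fold higher number from compound 2 to compound 3 (0.77 log units; beyond the scatter), and among these three compounds the lower number goes with nitro alone, not with the loss of chloro as such. Nothing available here accounts for this difference between nitro and cyano.

The compounds shown leave open whether an amine, a carboxylic acid or a methoxy group on this carbon would go with nitro or stay with chloro and cyano. They also leave open whether the nitro step would hold with the group on another carbon of the ring.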